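Nitro in place of iodo: expectation for compound 4

The source may report more compounds than this note shows. Statements on the series, on what has been measured and on what is new or still open speak of the compounds shown alone.

All values below come from a functional assay on U-87MG ATCC cells (Homo sapiens) for cytotoxicity, read by MTT assay, with a stated time of 48 h; a higher number here means a weaker inhibitor, a lower number a stronger inhibitor.

Compound 1, `C/C(=N/NC(=S)Nc1ccccc1I)c1ccccn1`: compound 1 gives 6.1 nM.
Compound 2, `C/C(=N\NC(=S)Nc1cccc(I)c1)c1ccccn1`: compound 2 gives 84 nM.
Compound 3, `C/C(=N/NC(=S)Nc1ccccc1[N+](=O)[O-])c1ccccn1`: compound 3 gives 4.3 nM.

Compound 1 and compound 2 are built from the same atoms joined differently; the difference between the two cores is not broken down here. Compound 2 has the highest number of the three, beyond the scatter from both compound 1 and compound 3.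

One change is measured once: nitro in place of iodo on an aromatic carbon. The step it made is a 1.4-fold lower number from compound 1 to compound 3 (0.15 log units; within the scatter).

The unmeasured compound 4, `C/C(=N\NC(=S)Nc1cccc([N+](=O)[O-])c1)c1ccccn1`, is reached from compound 2 by nitro in place of iodo on an aromatic carbon. Among the measured compounds shown here, the change is the same kind as the one from compound 1 to compound 3, not the same: there the nitro sits ortho to a large group, here meta to a large group. For the measured compounds named here, with only one measured example, and that within the scatter, the step from compound 2 to compound 4 in this assay is expected to be small, resting on the step of a 1.4-fold lower number from compound 1 to compound 3 (0.15 log units; within the scatter). The expected step is a 1.4-fold lower number from compound 2 to compound 4 (0.15 log units; within the scatter).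

Going by the values given here, compound 4 is estimated at 60 nM, with the range 20 nM to 250 nM reflecting that the single precedent stands at a different place on the ring.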

Compound 4, half-maximal inhibitory concentration: 69 nM
Compound 4: middle estimate off by 1.2-fold (0.06 log units), on the low side; measured number inside the range.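

In this assay, nitro in place of iodo can now be read on two cores, and the new step is a 1.2-fold lower number from compound 2 to compound 4 (0.09 log units; within the scatter). Set beside the earlier step, the two agree: the same change on two cores in this assay, a 1.4-fold lower number (0.15 log units; within the scatter) from compound 1 to compound 3 and a 1.2-fold lower number (0.09 log units; within the scatter) from compound 2 to compound 4, 1.2-fold (0.07 log units) apart, within the scatter of two such steps On these two cores, then, the exchange of iodo for nitro gives no difference that can be told from the scatter, and the step read on one core was a fair guide to the step on the other, even with the group at a different place on the ring; this does not show that the exchange would be equally silent on any further core or at any other ring position, and two pairs of small steps say nothing about why the numbers stay together.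

The compounds shown carry only iodo or nitro on this aromatic ring, so it remains open whether an amine, a carboxylic acid, a methoxy group or a plain hydrogen at the same carbon would also leave the number in place on both cores. Also open is what lies behind the gap between compound 1 and compound 2, which this exchange does not address.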